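Towards compound 4: swapping methoxycarbonyl for trifluoromethyl

The source may report more compounds than this note shows. Statements on the series, on what has been measured and on what is new or still open speak of the compounds shown alone.

Compound 1 `CC(=O)CCc1cc(C)c(Oc2cc(Nc3ccc(C#N)cc3)c(N)cc2C(F)(F)F)c(C)c1` gives > 5 (a limit)
Compound 2 `Cc1cc(CCC#N)cc(C)c1Oc1cc(Nc2ccc(C#N)cc2)c(N)cc1C(F)(F)F` gives > 5 (a limit)
Compound 3 `COC(=O)c1cc(N)c(Nc2ccc(C#N)cc2)cc1Oc1c(C)cc(/C=C/C#N)cc1C` gives 4.15 (a number)

Among the compounds with values here, in a physicochemical assay for lipophilicity, at pH 7.4 (a lower number here means a more polar compound, a higher number a more lipophilic compound), compound 3 gives 4.15 as the only true number so far. Compound 1 and compound 2 offer no number, only this: the limit of > 5 in this assay, at which 2 of the 3 values shown sit. Between those two stands a step that the two limits leave unreadable from compound 1 to compound 2 and no measured size carries over.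

Compound 4 `Cc1cc(/C=C/C#N)cc(C)c1Oc1cc(Nc2ccc(C#N)cc2)c(N)cc1C(F)(F)F` has trifluoromethyl in place of methoxycarbonyl on an aromatic carbon of compound 3, as counted here: trifluoromethyl in place of methoxycarbonyl on an aromatic carbon. Compound 2 carries the same trifluoromethyl, on a different chain, and gives > 5 as a limit, so a rise is expected in this assay with no measured size behind it. The expected change is a number 0.85 log units higher from compound 3 to compound 4 (beyond the scatter) as an estimate. For compound 4 the estimated value is 5 within a range of 4.6 to 5.4.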

Compound 4, partition coefficient: > 5
Compound 4: a limit, no number (the forecaster's own chance of this, stated with the estimate: 50%); the middle value lies on the limit itself.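

Swapping methoxycarbonyl for trifluoromethyl on this aromatic carbon gives the first step in this assay whose size can be read, at least in part: a number at least 0.85 log units higher from compound 3 to compound 4 (beyond the scatter). The value of compound 4, > 5, is a limit and not a number. The steps linking compound 4 to compound 1 and compound 2 cannot be read, and the series now sits mostly at one ceiling: the limit of > 5 in this assay, at which 3 of the 4 values shown sit.

Going by these compounds, how a carboxylic acid or an amine on this same aromatic carbon would read in this assay remains open. So does whether either would give a true number.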